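This account rests on a few compounds, and the source may have more. Where it says the series, first, only, none or still open, it means among the compounds named here.

Compound 1 `CNC(=O)c1cc(C(=O)NC2CC2)cn(Cc2ccc(OC)cc2)c1=O` gives 3 in a physicochemical assay for lipophilicity, at pH 7.4; on this read-out lower numbers stand for lower lipophilicity and higher numbers for higher lipophilicity. Among the three measured compounds it stands second highest: compound 2 `CNC(=O)c1cc(C(=O)NCCCC2CNCCO2)cn(Cc2ccccc2)c1=O` gives 1.4, and compound 3 `CNC(=O)c1cc(C(=O)NCCC(C)C)cn(Cc2ccccc2)c1=O` gives 4.8. Among the compounds with values here, the only single-point step measured so far, a number 3.40 log units higher from compound 2 to compound 3 (beyond the scatter), lies on the amide side chain and not at the position where compound 4 changes. Compound 4 `CNC(=O)c1cc(C(=O)NC2CC2)cn(CC2CCOCC2)c1=O` differs from compound 1 by oxan-4-yl in place of 4-methoxyphenyl on a saturated chain carbon bound to an aromatic nitrogen. Within the data shown here, no measured step touches this position, so the expectation rests on the change itself, in which 4-methoxyphenyl leaves and oxan-4-yl enters. A downward step of moderate size is expected, a number 1.10 log units lower from compound 1 to compound 4 (beyond the scatter). Compound 4 is therefore estimated at 1.9, with a range from 1.2 to 2.6.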

Compound 4, distribution coefficient: 1.5
Compound 4: the middle estimate sits 0.40 log units above what was measured; the range from low to high includes it.
By their numbers in this assay, from the lowest: compounds 2 and 4 (each within the scatter of the next); then compound 1; then compound 3.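

In this assay, the position on a saturated chain carbon bound to an aromatic nitrogen now has its first measured step: oxan-4-yl in place of 4-methoxyphenyl gives a number 1.50 log units lower from compound 1 to compound 4 (beyond the scatter). Within the data shown here, the step is large, so this position, which no earlier pair touched, is clearly sensitive to this change of ring. Nothing at hand explains the size of this step. The compounds shown leave open where a cyclohexyl or a piperidin-4-yl group at this position on the core of compound 1 would fall in this assay.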